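This account rests on a few compounds, and the source may have more. Where it says the series, first, only, none or still open, it means among the compounds named here.

- compound 1 `Cc1cc(Nc2nc(NCc3ccccc3Cl)nc3[nH]ncc23)n[nH]1` gives 4130 nM
- compound 2 `Cc1cc(Nc2nc(NCc3ccccc3Br)nc3[nH]ncc23)n[nH]1` gives 14100 nM
- compound 3 `Cc1cc(Nc2nc(NCc3ccc(F)cc3)nc3[nH]ncc23)n[nH]1` gives 970 nM

All three values come from a functional assay on MCF7 cells (Homo sapiens) for inhibition, read by MTT assay, with a stated time of 5 days; on this read-out lower numbers stand for stronger inhibition and higher numbers for weaker inhibition. Compound 3 has the lowest number of the three, and its gaps to the other two lie beyond the scatter (a 4.3-fold lower number from compound 1 to compound 3 (0.63 log units; beyond the scatter)) (a 15-fold lower number from compound 2 to compound 3 (1.16 log units; beyond the scatter)). Those two steps are modest and large, but each replaces more than a halogen, so neither shows what a halogen swap alone would do.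

Compound 4 `Cc1cc(Nc2nc(NCc3ccc(Cl)cc3)nc3[nH]ncc23)n[nH]1` differs from compound 3 in a single substituent: chloro in place of fluoro on an aromatic carbon, para to a large group (chloro in place of fluoro on an aromatic carbon).

The closest measured precedent is the modest rise on swapping chloro for bromo (a 3.4-fold higher number from compound 1 to compound 2 (0.53 log units; beyond the scatter)). Among the measured compounds shown here, it is only a loose guide, since it involves a different pair of halogens, and no measured compound shows fluoro giving way to chloro. A modest rise in the number is therefore expected, although a change within the scatter would be no surprise.

The expected step is a small one in that direction (a 1.5-fold higher number from compound 3 to compound 4 (0.19 log units; within the scatter)). For compound 4 the estimated value is 1500 nM, with an expected range from 600 nM to 4000 nM.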

Compound 4, half-maximal inhibitory concentration: 860 nM
Beside the measured number, compound 4's estimate is 1.7-fold (0.24 log units) above it; the range from low to high includes it.
By their numbers in this assay, from the lowest: compounds 4 and 3 (each within the scatter of the next); then compound 1; then compound 2.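

Swapping the halogen at this spot, para to a large group, leaves the number in this assay within the scatter (a 1.1-fold lower number from compound 3 to compound 4 (0.05 log units; within the scatter)), so fluoro and chloro cannot be told apart here, something no earlier pair could show. Among the compounds shown here, compound 4 also gives the first comparison in which chlorine stays and only its place on the ring changes: 4-chlorophenyl in place of 2-chlorophenyl gives a modest drop beyond the scatter (a 4.8-fold lower number from compound 1 to compound 4 (0.68 log units; beyond the scatter)), and 4-chlorophenyl in place of 2-bromophenyl, which alters both halogen and place, gives a large one (a 16-fold lower number from compound 2 to compound 4 (1.21 log units; beyond the scatter)). In these compounds, then, where the halogen sits counts for more than whether it is fluoro or chloro at the 4-position, although the swap of chloro for bromo at the 2-position goes against any rule that the halogen's identity never matters, and nothing available explains these differences.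

On these data alone, what a methoxy or a trifluoromethyl group would do at the 4-position remains open. So does whether a plain phenyl ring, with no halogen at all, would give a number like those of compound 3 and compound 4.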